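Swapping 2-fluorophenyl for 3-fluorophenyl on a shared core

The source may hold more compounds than are shown below. What is called first, only, known or untested is meant among the compounds shown, and "the series" means these compounds.

Compound 1 `COc1ccc(C2OC(c3ccc4ccccc4c3)=NN2C(C)=O)cc1`: 3.6 ug/mL
Compound 2 `CC(=O)N1N=C(c2ccc3ccccc3c2)OC1c1ccccc1F`: 3.36 ug/mL

In a functional assay on HepG2 cells (Homo sapiens) for antiproliferative activity, read by MTT assay, with a stated time of 48 h (a higher number here means a weaker inhibitor, a lower number a stronger inhibitor), only these two compounds have been measured so far. Compound 2, at 3.36 ug/mL, lies within the scatter of compound 1, so neither can be ranked above the other.

The next molecule is compound 3 `CC(=O)N1N=C(c2ccc3ccccc3c2)OC1c1cccc(F)c1`. It carries 3-fluorophenyl in place of 2-fluorophenyl on a saturated ring carbon, and the rest of the molecule is unchanged: 3-fluorophenyl in place of 2-fluorophenyl on a saturated ring carbon.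

For the measured compounds named here, only one measured step bears on this change: a 1.1-fold lower number from compound 1 to compound 2 (0.03 log units; within the scatter). That step altered the same ring carbon, replacing 4-methoxyphenyl with 2-fluorophenyl, and it stayed within the scatter. Going by the values given here, this is thin evidence, as no measured compound carries 3-fluorophenyl and no measured step compares two placements of fluorine. Even so, no change beyond the scatter is expected in this assay, in either direction. The estimated step is a 1.0-fold higher number from compound 2 to compound 3 (0.01 log units; within the scatter). The estimated value of compound 3 is 3.4 ug/mL, with an expected range of 1.7 ug/mL to 6.8 ug/mL.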

Compound 3, half-maximal inhibitory concentration: 1.86 ug/mL
Compound 3: middle estimate off by 1.8-fold (0.26 log units), on the high side, within the range that was stated.
By their numbers in this assay, from the lowest: compounds 3, 2 and 1 (each within the scatter of the next).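

In this assay, for the compounds shown here, the first direct comparison of two fluorine placements on this saturated ring carbon gives a 1.8-fold lower number from compound 2 to compound 3 (0.26 log units; within the scatter), so swapping 2-fluorophenyl for 3-fluorophenyl produces no change that can be told apart from ordinary measurement scatter. The comparison with the non-fluorinated group gives a 1.9-fold lower number from compound 1 to compound 3 (0.29 log units; within the scatter), and this also counts as within the scatter, so 4-methoxyphenyl, 2-fluorophenyl and 3-fluorophenyl cannot be ranked against one another at this position. No independent measurement is available that could explain these numbers.

On these data alone, all three compounds carry a substituted phenyl group on this ring carbon, so it remains open whether an amine, a carboxylic acid or a longer alkyl chain in that place would give a step beyond the scatter. The acetyl group is also the same throughout, which leaves open how replacing it with a longer chain or an amine would affect the number in this assay when the rest of the shared core is kept unchanged.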